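Swapping a Nitro Group for Hydroxy on a Cyanoacrylamide

A few compounds are considered here, and "the series" means these few. Any claim that something is new, unique, unknown or untested is made for them only; others in the source may bear on it.

Of the compounds shown here, two sharing one core have been measured so far. Compound 1 `N#C/C(=C/c1ccc(Cl)cc1)C(=O)c1ccc[nH]1` gives 84000 nM in a functional assay on MCF7 cells (Homo sapiens) for cytotoxicity, read by MTT assay, with a stated time of 72 h; a higher number here means a weaker inhibitor of growth, a lower number a stronger inhibitor of growth. Compound 2 `N#C/C(=C/c1ccc([N+](=O)[O-])cc1)C(=O)c1ccc[nH]1` gives 19000 nM in this assay, the lowest of the two numbers. Within the data shown here, the single measured step, a 4.4-fold lower number from compound 1 to compound 2 (0.65 log units; beyond the scatter), is modest and beyond the usual scatter.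

Compound 3 `N#C/C(=C/c1ccc(O)cc1)C(=O)c1ccc[nH]1` is not yet measured. Its change from compound 2 is hydroxy in place of nitro on an aromatic carbon. Among the measured compounds shown here, no measured step here exchanges nitro for hydroxy, so the only guide is that the one change at this position, a 4.4-fold lower number from compound 1 to compound 2 (0.65 log units; beyond the scatter), shifted the number by a modest amount. A comparable or smaller shift in either direction is therefore expected, with some lean toward a higher number since compound 2 already holds the lowest value. Compound 3 is estimated at 40000 nM, with a range from 10000 nM to 150000 nM. This expected step is a 2.1-fold higher number from compound 2 to compound 3 (0.32 log units; beyond the scatter).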

Compound 3, concentration for 50% growth inhibition: 15000 nM
Beside the measured number, compound 3's estimate is 2.7-fold (0.43 log units) above it; low and high end bracket the measured number.
By their numbers in this assay, from the lowest: compounds 3 and 2 (each within the scatter of the next); then compound 1.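

Replacing nitro with hydroxy gives a 1.3-fold lower number from compound 2 to compound 3 (0.10 log units; within the scatter) in this assay, so at this position on the aromatic ring the two groups cannot be told apart, even though they differ in heavy atoms and in hydrogen-bond donors. Hydroxy in place of chloro gives a 5.6-fold lower number from compound 1 to compound 3 (0.75 log units; beyond the scatter), a modest step much like a 4.4-fold lower number from compound 1 to compound 2 (0.65 log units; beyond the scatter), so among these three compounds chloro alone stands apart, while nitro and hydroxy sit together at the lower numbers. Nothing on hand explains why these groups give the numbers they do.

Going by these compounds, it remains open whether an amine or a carboxylic acid at this position would sit with nitro and hydroxy or with chloro. A longer chain such as ethoxy is equally untested here, and three compounds cannot show whether any trend extends beyond them.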